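The source may report more compounds than this note shows. Statements on the series, on what has been measured and on what is new or still open speak of the compounds shown alone.

Working notes on the series, read in a functional assay on cells (Homo sapiens) for cytotoxicity, read by MTT assay, with a stated time of 24 h; on this read-out lower numbers stand for stronger inhibition and higher numbers for weaker inhibition. Compound 1 (`CCCCCCCCCCCCCCNC(=O)[C@H](CO)/N=C/c1cccc(C)c1`) gives 82900 nM, compound 2 (`CCCCCCCCCCCCCCNC(=O)[C@H](CO)/N=C/c1ccc(OC)cc1`) gives 28100 nM and compound 3 (`CCCCCCCCCCCCCCNC(=O)[C@H](CO)/N=C/c1ccc(O)cc1`) gives 19300 nM. Compound 3 therefore sits level with compound 2 within the scatter, and both sit under compound 1.

Compound 4 (`CCCCCCCCCCCCCCNC(=O)[C@H](CO)NCc1ccccc1Cl`) carries this change from compound 3: a group of 9 heavy atoms (7 carbon, 1 nitrogen, 1 chlorine; one six-membered aromatic ring of carbon only) in place of a group of 9 heavy atoms (7 carbon, 1 nitrogen, 1 oxygen; one six-membered aromatic ring of carbon only), on a saturated chain carbon bound to a carbonyl carbon and a saturated chain carbon. For the measured compounds named here, the (2-chlorobenzyl)amino group appears in no measured compound, so no measured step covers this change directly. The nearest evidence comes from the swaps of the aromatic group, which gave a 3.0-fold lower number from compound 1 to compound 2 (0.47 log units; beyond the scatter) and a 4.3-fold lower number from compound 1 to compound 3 (0.63 log units; beyond the scatter), both modest. Removing the methyl on the oxygen gave only a 1.5-fold lower number from compound 2 to compound 3 (0.16 log units; within the scatter). These steps give no direction for the new change, and they suggest a small step at most in this assay.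

The expected step is a 1.3-fold lower number from compound 3 to compound 4 (0.11 log units; within the scatter), with no shift beyond the scatter expected. The estimate for compound 4 is 15000 nM, with an expected range of 5000 nM to 45000 nM.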

Compound 4, half-maximal inhibitory concentration: 43700 nM
Beside the measured number, compound 4's estimate is 2.9-fold (0.46 log units) below it, within the range that was stated.
By their numbers in this assay, from the lowest: compounds 3, 2, 4 and 1 (each within the scatter of the next, the first and the last beyond it).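

In this assay, the (2-chlorobenzyl)amino group, which has no double bond outside the aromatic ring, gives a 2.3-fold higher number from compound 3 to compound 4 (0.35 log units; beyond the scatter), a modest step that shows compound 3 keeps a real edge over this group at this position. The other two steps, a 1.6-fold higher number from compound 2 to compound 4 (0.19 log units; within the scatter) and a 1.9-fold lower number from compound 1 to compound 4 (0.28 log units; within the scatter), both lie within the scatter, so keeping the double bond is not needed for a number level with those of compound 2 and compound 1. Nothing measured here explains the step from compound 3.

On these data alone, the change to compound 4 replaces both the double bond and the ring substituent at once, so the share of each stays open. A 4-hydroxybenzylamino group or a 2-chlorophenyl group on the carbon with the double bond to nitrogen would separate the two.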